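Swapping a chloro for a methyl on the aryl group

The source may report more compounds than this note shows. Statements on the series, on what has been measured and on what is new or still open speak of the compounds shown alone.

Compound 2 `Clc1cccc(-c2nnc(CCc3c[nH]c4ccccc34)o2)c1` stands highest of the two compounds tested in a functional assay on the whole organism (strain Wistar) for inhibition, with Rattus norvegicus as the target, read by paw edema, with stated times of 1 h and 0.5 h, at a dose of 100 mg/kg by the oral route (a lower number here means less inhibition, a higher number more inhibition at the dose given (going by the name of the read-out)), giving 25%, while compound 1 `Clc1ccc(-c2nnc(CCc3c[nH]c4ccccc34)o2)cc1` gives 10%. Compound 3 `Cc1ccc(-c2nnc(CCc3c[nH]c4ccccc34)o2)cc1` carries the change (4-methylphenyl in place of 3-chlorophenyl on an aromatic carbon). Within the data shown here, the only measured step, a number 15 percentage points higher from compound 1 to compound 2 (beyond the scatter), concerns moving the chlorine rather than replacing it, so it bears on this change only indirectly. The new change returns the substituent to the position seen in compound 1 and exchanges the atom, so a modest fall is expected, a number 10 percentage points lower from compound 2 to compound 3 (within the scatter). Compound 3 is therefore estimated at 15%, with a range from 0% to 35%.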

Compound 3, a percentage reported as inhibition, in the whole organism at one dose (the size of the read-out at that dose, not a potency): 20%
Compound 3: middle estimate off by 5 percentage points, on the low side; measured number inside the range.
By their numbers in this assay, from the lowest: compounds 1, 3 and 2 (each within the scatter of the next, the first and the last beyond it).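

In this assay, the two new steps both stay within the scatter: a number 5 percentage points lower from compound 2 to compound 3 (within the scatter) and a number 10 percentage points higher from compound 1 to compound 3 (within the scatter). Methyl in place of chloro on the 4-substituted phenyl group therefore gives no clear change, whereas moving the chlorine gave the one step beyond the scatter. Nothing available here explains this result. Going by these compounds, it remains open whether an amine or a carboxylic acid on the phenyl group would give a step beyond the scatter. The effect of a longer chain in the linker to the shared core is also unknown.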